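The source may report more compounds than this note shows. Statements on the series, on what has been measured and on what is new or still open speak of the compounds shown alone.

Compound 1 `CCCCCCCCCCCCSC[C@H](NC(C)=O)C(=O)C=[N+]=[N-]` and compound 2 `CCCCCCCCCCCCSC[C@H](NC(C)=O)C(=O)CCl` share one core and differ in a single place: a group of 2 heavy atoms (1 carbon, 1 chlorine; no ring) in place of a group of 3 heavy atoms (1 carbon, 2 nitrogen; no ring), on a carbonyl carbon. In a functional assay on NALM-6 cells (Homo sapiens) (a higher number here means a weaker inhibitor, a lower number a stronger inhibitor), compound 1 gives 15400 nM, while compound 2 gives 2000 nM, so this change gave a 7.7-fold lower number from compound 1 to compound 2 (0.89 log units; beyond the scatter). Compound 3 `CC(C)=CCC/C(C)=C/CC/C(C)=C/CSC[C@H](NC(=O)CNC(=O)OC(C)(C)C)C(=O)C=[N+]=[N-]` is built on a different core; how that core differs from the core of compound 1 is not broken down here. In this assay compound 3 gives 51300 nM, the highest of the three numbers. Compound 4 `CC(C)=CCC/C(C)=C/CC/C(C)=C/CSC[C@H](NC(=O)CNC(=O)OC(C)(C)C)C(=O)CCl` has not yet been measured. It comes from compound 3 by the same change, at the same place: a group of 2 heavy atoms (1 carbon, 1 chlorine; no ring) in place of a group of 3 heavy atoms (1 carbon, 2 nitrogen; no ring), on a carbonyl carbon. Because the same change gave a 7.7-fold lower number from compound 1 to compound 2 (0.89 log units; beyond the scatter) the expected step here is of about that size, a 7.3-fold lower number from compound 3 to compound 4 (0.87 log units; beyond the scatter). Compound 4 is therefore estimated at 7000 nM, with a likely range from 2500 nM to 20000 nM.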

Compound 4, half-maximal inhibitory concentration: 12900 nM
For compound 4 the middle estimate is 1.8-fold (0.27 log units) below the measured one; measured number inside the range.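

Putting chloromethyl on the carbonyl carbon again lowers the number in this assay, giving a 4.0-fold lower number from compound 3 to compound 4 (0.60 log units; beyond the scatter). The change therefore carries over from one core to the other in direction, and the two step sizes cannot be told apart: the same change on two cores in this assay, a 7.7-fold lower number (0.89 log units; beyond the scatter) from compound 1 to compound 2 and a 4.0-fold lower number (0.60 log units; beyond the scatter) from compound 3 to compound 4, 1.9-fold (0.29 log units) apart, within the scatter of two such steps. Among these compounds, this rests on only two pairs, so it shows that the change held on these two cores, but not that it would hold on any other core or why the number falls.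

The compounds shown leave open how other groups on the carbonyl carbon, such as bromomethyl or fluoromethyl, would compare. They also leave open whether the step stays similar on a core with a shorter chain.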